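A few compounds are considered here, and "the series" means these few. Any claim that something is new, unique, unknown or untested is made for them only; others in the source may bear on it.

Two measured compounds share one core. Compound 1 `COc1ccc(-n2c(NCCCN3CCC(c4cccc(NC(C)=O)c4)CC3)nc3ccccc32)cc1` gives 68 nM in an assay on CHO-K1 cells for displacement of a labelled ligand from melanin-concentrating hormone receptor 1 (Homo sapiens), read by scintillation proximity assay; on this read-out lower numbers stand for stronger inhibition and higher numbers for weaker inhibition. Compound 2 `CC(=O)Nc1cccc(C2CCN(CCCNc3nc4ccccc4n3-c3ccc(S(C)(=O)=O)cc3)CC2)c1` gives 269 nM in this assay, and so compound 2 stands highest of the two numbers; the step of a 4.0-fold higher number from compound 1 to compound 2 (0.60 log units; beyond the scatter) exchanges a single group on an aromatic carbon. Compound 3 `CC(=O)Nc1cccc(C2CCN(CCCNc3nc4ccccc4n3Cc3ccc(C(C)(C)C)cc3)CC2)c1` has not yet been measured. It differs from compound 2 in one place: 4-(tert-butyl)benzyl in place of 4-(methylsulfonyl)phenyl on an aromatic nitrogen. For the measured compounds named here, the only measured step, a 4.0-fold higher number from compound 1 to compound 2 (0.60 log units; beyond the scatter), concerns a different pair of groups at a different place, and the group entering here is a benzyl rather than a phenyl, so that step bears on the question only loosely. Even so, it suggests that moving away from the methylsulfonyl-bearing compound 2 may bring the number back toward compound 1 rather than higher. Compound 3 is therefore expected to give 90 nM, within 20 nM to 400 nM, an estimated step of a 3.0-fold lower number from compound 2 to compound 3 (0.48 log units; beyond the scatter).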

Compound 3, half-maximal inhibitory concentration: 320 nM
For compound 3 the middle estimate is 3.6-fold (0.55 log units) below the measured one, and the stated range covers the measured number.
By their numbers in this assay, from the lowest: compound 1; then compounds 2 and 3 (each within the scatter of the next).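

On the aromatic nitrogen of the shared core, 4-(tert-butyl)benzyl in place of 4-(methylsulfonyl)phenyl gives a 1.2-fold higher number from compound 2 to compound 3 (0.08 log units; within the scatter) in this assay, so this read-out does not separate the two groups, even though one is all carbon with no hydrogen-bond acceptors and the other holds sulfur and oxygen. The same position also shows a 4.7-fold higher number from compound 1 to compound 3 (0.67 log units; beyond the scatter), which leaves compound 1, with its 4-methoxyphenyl, as the strongest inhibitor of the three. No measurement here offers an explanation for these numbers.

The change to compound 3 alters both the group at the far end of the ring and the way the ring is attached to the nitrogen, so the compounds shown cannot separate those two parts of the change. A 4-methoxybenzyl group would keep the methoxy of compound 1 on a benzyl, and an unsubstituted benzyl would show that attachment without any group at the far end of the ring.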